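The source may report more compounds than this note shows. Statements on the series, on what has been measured and on what is new or still open speak of the compounds shown alone.

Compound 3 `O=C(Nc1ccc(S(=O)(=O)Nc2nccs2)cc1)c1cn(Cc2c(F)cccc2F)c2ccc(=O)[nH]c2c1=O` gives 25 nM in an in vitro assay on Sf21 cells for inhibition of high affinity 3',5'-cyclic-AMP phosphodiesterase 7A (Homo sapiens), read by scintillation proximity assay, with a stated time of 30 min; a lower number here means a stronger inhibitor, a higher number a weaker inhibitor. Compound 1 `CCN(CC)c1ccc(NC(=O)c2cn(Cc3c(F)cccc3F)c3ccc(=O)[nH]c3c2=O)cc1` gives 46 nM in this assay, and compound 2 `O=C(Nc1ccccc1)c1cn(Cc2c(F)cccc2F)c2ccc(=O)[nH]c2c1=O` gives 94 nM. Of these three numbers that of compound 3 is the lowest, yet its gap to compound 1 lies within the scatter, so only compound 2 is clearly separated from it. The three measured steps are a 2.0-fold higher number from compound 1 to compound 2 (0.31 log units; beyond the scatter), a 1.8-fold lower number from compound 1 to compound 3 (0.26 log units; within the scatter) and a 3.8-fold lower number from compound 2 to compound 3 (0.58 log units; beyond the scatter), and each of them exchanges a group on an aromatic carbon of a part of the molecule that the next change leaves untouched. Compound 4 `O=C(Nc1ccc(S(=O)(=O)Nc2nccs2)cc1)c1cn(Cc2c(F)cccc2Cl)c2ccc(=O)[nH]c2c1=O` differs from compound 3 in the benzyl part: chloro in place of fluoro on an aromatic carbon. No measured step concerns this part of the molecule, so nothing among the shown data bears directly on the change, and no step beyond the scatter is expected. Compound 4 is therefore expected to sit close to compound 3, no change at the digits printed from compound 3 to compound 4 (within the scatter). The estimate for compound 4 in this assay is 25 nM, with a range from 10 nM to 65 nM.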

Compound 4, half-maximal inhibitory concentration: 32 nM
For compound 4 the middle estimate is 1.3-fold (0.11 log units) below the measured one; low and high end bracket the measured number.
By their numbers in this assay, from the lowest: compounds 3, 4 and 1 (each within the scatter of the next); then compound 2.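

Until now every measured step lay on the anilide ring, so the benzyl part had no reading of its own. The change from 2,6-difluorobenzyl to 2-chloro-6-fluorobenzyl, with chloro entering on an aromatic carbon ortho to a large group, gives a 1.3-fold higher number from compound 3 to compound 4 (0.11 log units; within the scatter) in this assay, which shows that this place tolerates the exchange when the (1,3-thiazol-2-yl)sulfamoyl group is present. No measurement at hand gives a reason for this outcome.

Going by these compounds, this is a single exchange in a single setting, so it remains open whether chloro would read the same alongside the diethylamino group or on the plain phenyl amide. On these data alone, it is also open how bromo, methoxy or hydrogen would read at this place, or what replacing the remaining fluoro would do.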